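A few compounds are considered here, and "the series" means these few. Any claim that something is new, unique, unknown or untested is made for them only; others in the source may bear on it.

Measured compounds:
- compound 1, `CCOc1nc2ccccn2c(=N)c1S(=O)(=O)c1ccccc1`: 12 nM
- compound 2, `CSc1nc2ccccn2c(=N)c1S(=O)(=O)c1ccc(F)cc1`: 22 nM
- compound 3, `CNc1nc2ccccn2c(=N)c1S(=O)(=O)c1ccccc1`: 2.4 nM

In an assay on HeLa cells for displacement of a labelled ligand from 5-hydroxytryptamine receptor 6 (Homo sapiens) (on this read-out lower numbers stand for stronger inhibition and higher numbers for weaker inhibition), compound 3 gives the lowest of the three numbers. Among the compounds with values here, compound 1 stands nearest to it, and the only single-point step measured, a 5.0-fold lower number from compound 1 to compound 3 (0.70 log units; beyond the scatter), replaces an ethoxy group with methylamino on an aromatic carbon. Compound 2 gives a higher number still, but it differs from compound 3 in two places, so only its value can be set beside that of compound 3.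

Compound 4, `N=c1c(S(=O)(=O)c2ccccc2)c(NCCO)nc2ccccn12`, carries hydroxymethyl in place of hydrogen on a saturated chain carbon bound to a nitrogen on an aromatic ring; the methylamino of compound 3 thus becomes (2-hydroxyethyl)amino. Within the data shown here, no measured step touches this chain carbon: the one step known concerns the exchange of the whole group on the aromatic carbon and says nothing about lengthening the chain attached to the nitrogen. With the shared core, the sulfonyl substituent and the amino attachment all kept, compound 4 is expected to stay close to compound 3, and any step is expected to be small. Compound 4 is therefore estimated at 4 nM, within a range of 1.5 nM to 12 nM, corresponding to an expected step of a 1.7-fold higher number from compound 3 to compound 4 (0.22 log units; within the scatter).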

Compound 4, half-maximal inhibitory concentration: 42 nM
The estimate for compound 4 lay 11-fold (1.02 log units) below the measured number; the whole stated range lies below it.
By their numbers in this assay, from the lowest: compound 3; then compounds 1, 2 and 4 (each within the scatter of the next, the first and the last beyond it).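

In this assay, the chain on the nitrogen proves to be far from neutral: hydroxymethyl in place of hydrogen on a saturated chain carbon bound to a nitrogen on an aromatic ring gives an 18-fold higher number from compound 3 to compound 4 (1.24 log units; beyond the scatter), a large step for an addition of 2 heavy atoms. An amino attachment alone does not secure the lower number either, as exchanging the ethoxy group for (2-hydroxyethyl)amino gives a 3.5-fold higher number from compound 1 to compound 4 (0.54 log units; beyond the scatter), the opposite direction to the step seen with methylamino. Nothing available explains why this chain extension costs so much.

The compounds shown leave open whether the step goes with the longer chain or with the hydroxyl at its end; an ethylamino or a (2-methoxyethyl)amino group here would separate the two. As far as these compounds go, how a (2-aminoethyl)amino group or a chain ending in a carboxylic acid would read also remains open.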